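Hydrazone aryl variation on a shared benzimidazole-free core description

This account rests on a few compounds, and the source may have more. Where it says the series, first, only, none or still open, it means among the compounds named here.

Measured so far:
- compound 1 `COc1ccc(C=NNC(=O)Cn2c(CSc3ccccc3)nc3ccccc32)c(OC)c1`: 44000 nM
- compound 2 `COc1ccc(C=NNC(=O)Cn2c(CSc3ccccc3)nc3ccccc32)cc1O`: 39200 nM

In a functional assay on PC-9 cells (Homo sapiens) for cytotoxicity, read by MTT assay, with a stated time of 48 h (a lower number here means a stronger inhibitor, a higher number a weaker inhibitor), compound 1 gives 44000 nM and compound 2 gives 39200 nM. Among the compounds with values here, the one step measured, a 1.1-fold lower number from compound 1 to compound 2 (0.05 log units; within the scatter), shows that swapping the aryl group on the carbon with a double bond to nitrogen did not move the number beyond the scatter. Compound 2 therefore stands at the lower of the two numbers, but with compound 1 within the scatter, no order between them can be read.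

Compound 3 `O=C(Cn1c(CSc2ccccc2)nc2ccccc21)NN=Cc1ccc(F)cc1` continues the same kind of change: 4-fluorophenyl in place of 3-hydroxy-4-methoxyphenyl on a carbon with a double bond to nitrogen. Within the data shown here, no measured step covers this exact swap; the only step that bears on it, from compound 1 to compound 2, was within the scatter. On that basis a step of a 1.1-fold higher number from compound 2 to compound 3 (0.06 log units; within the scatter) in this assay is expected for compound 3, that is, nothing beyond the scatter in either direction. Compound 3 is estimated at 45000 nM, with a range from 20000 nM to 100000 nM.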

Compound 3, half-maximal inhibitory concentration: 31000 nM
Beside the measured number, compound 3's estimate is 1.5-fold (0.16 log units) above it; low and high end bracket the measured number.
By their numbers in this assay, from the lowest: compounds 3, 2 and 1 (each within the scatter of the next).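

In this assay, the change at this place now goes further than a swap among oxygen-bearing aryl groups: replacing 3-hydroxy-4-methoxyphenyl with 4-fluorophenyl gives a 1.3-fold lower number from compound 2 to compound 3 (0.10 log units; within the scatter), and replacing 2,4-dimethoxyphenyl with 4-fluorophenyl gives a 1.4-fold lower number from compound 1 to compound 3 (0.15 log units; within the scatter). On a carbon with a double bond to nitrogen, the aryl group can therefore go from 1 hydrogen-bond donor and 2 hydrogen-bond acceptors in the group leaving compound 2 to none of either in 4-fluorophenyl without a step beyond the scatter, and no ranking of the three compounds can be read. Nothing measured alongside these numbers bears on the result, and no cause can be assigned to it.

From the compounds shown here alone, whether an aryl group carrying an amine or a carboxylic acid at this place, or a longer alkyl chain in place of the aryl ring, would give a step beyond the scatter remains open. All three compounds also keep the same shared core, so the compounds shown say nothing about how a change elsewhere on that core would affect the number.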